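This account rests on a few compounds, and the source may have more. Where it says the series, first, only, none or still open, it means among the compounds named here.

Measured so far in an ADME assay (liver) for pharmacokinetics, with Liver microsome (Rattus norvegicus) as the target, using microsomes; on this read-out lower numbers stand for slow clearance and higher numbers for fast clearance:

Compound 1 `CNc1nc(NCc2ccc(Cl)cc2Cl)cc(-c2ccccn2)n1` gives > 52.3 mL/min/kg
Compound 2 `O=S(=O)(NC[C@H]1CC[C@H](CNc2nc(NC3CC3)cc(-c3ccccn3)n2)CC1)c1cccc(F)c1` gives 51.2 mL/min/kg
Compound 3 `CNc1nc(NCc2ccc(NC(C)=O)cc2)cc(-c2ccccn2)n1` gives 35.9 mL/min/kg

The entry for compound 1 of > 52.3 mL/min/kg is a limit of the assay and not a number. Compound 3 at 35.9 mL/min/kg and compound 2 at 51.2 mL/min/kg lie within the usual scatter of each other.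

Compound 4 `CNc1nc(NCc2ccc(NS(C)(=O)=O)cc2)cc(-c2ccccn2)n1` carries methylsulfonyl in place of acetyl on a nitrogen on an aromatic ring. Going by the values given here, no measured pair of compounds shows this change. In this assay no step beyond the scatter is expected, and no firm direction can be named. The estimated step of a 1.1-fold lower number from compound 3 to compound 4 (0.05 log units; within the scatter) is therefore small. Compound 4 is expected to read 32 mL/min/kg with an estimated range of 18 mL/min/kg to 52 mL/min/kg in this measurement.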

Compound 4, clearance: 33.6 mL/min/kg
For compound 4 the middle estimate is 1.1-fold (0.02 log units) below the measured one, within the range that was stated.
By their numbers in this assay, from the lowest: compounds 4, 3 and 2 (each within the scatter of the next). At a limit, above all of these: compound 1.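

Among the compounds shown, this is the first pair that differs in one place, so the effect of a single change can be read in this assay. Putting methylsulfonyl in place of acetyl on a nitrogen on an aromatic ring gives a 1.1-fold lower number from compound 3 to compound 4 (0.03 log units; within the scatter), so the two groups cannot be told apart on this read-out. Compound 3 and compound 4 both give real numbers rather than a limit, which makes this comparison readable: the limit of > 52.3 mL/min/kg in this assay, at which 1 of the 4 values shown sits.

Going by these compounds, whether a longer chain such as propionyl on that nitrogen, or a free amine in place of the acetamido group, would read alike stays open. A single pair also cannot show whether this swap reads the same on a different core.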